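Pyridin-2-yl in place of 3-bromophenyl on the shared core

The compounds below may be only part of what the source reports. "The series", "measured", "known", "first", "only" and "open" are said of these compounds alone.

Measured in an assay on isolated protein for inhibition of 3-hydroxy-3-methylglutaryl-coenzyme A reductase (Homo sapiens); on this read-out lower numbers stand for stronger inhibition and higher numbers for weaker inhibition:
compound 1 `CNc1cccc(-c2nc(C(C)C)n(/C=C/[C@@H](O)C[C@@H](O)CC(=O)O)c2-c2ccc(F)cc2)c1`: 8.52 nM
compound 2 `CC(C)c1cc(-c2ccc(F)cc2)c(-c2ccc(F)cc2)n1/C=C/[C@@H](O)C[C@@H](O)CC(=O)O`: 8.7 nM; 6.98 nM (2 entries)
compound 3 `CC(C)c1cc(-c2cccc(Br)c2)c(-c2ccc(F)cc2)n1/C=C/[C@@H](O)C[C@@H](O)CC(=O)O`: 9.3 nM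

All three values sit close together. Compound 3, in this assay, gives 9.3 nM, and compound 1 gives 8.52 nM, a gap within the scatter. Compound 2 is represented by several entries (the several entries of compound 2 in this assay, 8.7 nM; 6.98 nM (2 entries)), which together frame the same narrow band.

Compound 4 `CC(C)c1cc(-c2ccccn2)c(-c2ccc(F)cc2)n1/C=C/[C@@H](O)C[C@@H](O)CC(=O)O` differs from compound 3 in one place: pyridin-2-yl in place of 3-bromophenyl on an aromatic carbon. Among the compounds with values here, no pair of measured compounds isolates this change, so no measured step guides it. With the aryl groups on this carbon so far giving similar numbers, the expected step from compound 3 to compound 4 is a 1.5-fold higher number from compound 3 to compound 4 (0.18 log units; within the scatter), small and not clearly beyond the scatter. For compound 4 the estimate is 14 nM, with a range from 5 nM to 45 nM.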

Compound 4, half-maximal inhibitory concentration: 8.7 nM
Compound 4: middle estimate off by 1.6-fold (0.21 log units), on the high side; the measured number falls inside the stated range.
By their numbers in this assay, from the lowest: compounds 1, 4 and 3 (each within the scatter of the next).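

Within the data shown here, this gives the first measured step at this aromatic carbon, next to the ring atom that bears a 4-fluorophenyl group. In this assay, pyridin-2-yl, with its ring nitrogen and hydrogen-bond acceptor, replaces 3-bromophenyl with a 1.1-fold lower number from compound 3 to compound 4 (0.03 log units; within the scatter), so the all-carbon ring and the bromine are not needed to keep the number in this band. The step is no larger than the spread among repeat entries of a single compound: the several entries of compound 2 in this assay, 8.7 nM; 6.98 nM (2 entries)

Still open, from the compounds shown here alone, is whether the ring nitrogen's location matters, as pyridin-3-yl would show. Also open, going by these compounds, is whether a non-aromatic group on this carbon, such as a carboxylic acid or a primary amine on a longer chain, would hold the same band.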